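This account rests on a few compounds, and the source may have more. Where it says the series, first, only, none or still open, it means among the compounds named here.

Measured so far in a functional assay on HCT-116 cells (Homo sapiens) for cytotoxicity, read by MTT assay, with a stated time of 48 h; a higher number here means a weaker inhibitor, a lower number a stronger inhibitor:
Compound 1 `CCN(CC)c1ccc2cc(C(=O)c3ccc(N4CCN(C(=O)CN5CCN(C(=O)CCl)CC5)CC4)cc3)oc2c1` gives > 40000 nM, a limit of the assay.
Compound 2 `CCN(CC)c1ccc2cc(C(=O)c3ccc(N4CCN(C(=O)CN5CCN(S(=O)(=O)C6CC6)CC5)CC4)cc3)oc2c1` gives > 40000 nM, also a limit.
Compound 3 `CCN(CC)c1ccc2cc(C(=O)c3ccc(N4CCN(C(=O)CN5CCN(S(=O)(=O)c6ccc(C(F)(F)F)cc6)CC5)CC4)cc3)oc2c1` gives 32200 nM.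

Compound 2 stands at the limit of > 40000 nM in this assay, at which 2 of the 3 values shown sit; its value is a limit, not a number. The step that the two limits leave unreadable from compound 1 to compound 2 is therefore unreadable. The step of an at least 1.2-fold lower number from compound 2 to compound 3 (0.09 log units; that floor lies within the scatter) has a floor that lies within the scatter. Compound 4 `C#CCN1CCN(CC(=O)N2CCN(c3ccc(C(=O)c4cc5ccc(N(CC)CC)cc5o4)cc3)CC2)CC1` differs from compound 2 in one place: propargyl in place of cyclopropylsulfonyl on an amine nitrogen in a ring. Within the data shown here, none of the measured steps touches this change, and each ends in a limit or a weak value. No shift beyond the scatter is expected in this assay. Compound 4 is expected to give 45000 nM, with a range from 15000 nM to 120000 nM. This estimate means an expected step that the limit leaves unreadable from compound 2 to compound 4, with a fair chance that only a limit is reported.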

Compound 4, half-maximal inhibitory concentration: 17700 nM
Estimate against measurement, compound 4: 2.5-fold (0.41 log units) above, within the range that was stated.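

In this assay, the group on this amine nitrogen in a ring can shift the number beyond the scatter: propargyl gives an at least 2.2-fold lower number from compound 2 to compound 4 (0.35 log units; beyond the scatter), and it also gives an at least 2.2-fold lower number from compound 1 to compound 4 (0.35 log units; beyond the scatter). Compound 1 and compound 2 each stand at a limit, so these steps are floors and the step between those two cannot be read: the limit of > 40000 nM in this assay, at which 2 of the 4 values shown sit. Compound 4 is the only one shown with neither a sulfonyl nor a carbonyl on this nitrogen. From the compounds shown here alone, the true sizes of both steps stay open. So does whether the triple bond matters, which a propyl chain in place of propargyl would address.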